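The compounds below may be only part of what the source reports. "The series", "measured", "known", "first", "only" and "open" are said of these compounds alone.

Of the compounds shown here, three have so far been measured in an ADME assay on BJ cells (Homo sapiens), read by MTT assay, with a stated time of 72 h; a lower number here means a stronger inhibitor, a higher number a weaker inhibitor. Compound 1 `C#Cc1cn([C@@H]2O[C@H](CO)[C@@H](O)[C@H]2O)c2ncnc(OC)c12` gives 98400 nM, compound 2 `C#Cc1cn([C@@H]2O[C@H](CO)[C@@H](O)[C@H]2O)c2ncnc(N(C)C)c12` gives 410 nM, and compound 3 `COc1ncnc2c1c(-c1ccoc1)cn2[C@@H]1O[C@H](CO)[C@@H](O)[C@H]1O` gives 28800 nM, the second highest of the three numbers. Among the measured changes, a 3.4-fold lower number from compound 1 to compound 3 (0.53 log units; beyond the scatter) was modest, and compound 3 gives a clearly higher number than compound 2. Compound 4 `CN(C)c1ncnc2c1c(-c1ccoc1)cn2[C@@H]1O[C@H](CO)[C@@H](O)[C@H]1O` has not yet been measured; it differs from compound 3 by dimethylamino in place of methoxy on an aromatic carbon. For the measured compounds named here, the one measured step of exactly this kind, a 240-fold lower number from compound 1 to compound 2 (2.38 log units; beyond the scatter), was large, so a large drop is expected here too, though only a single example supports it. Compound 4 is therefore estimated at 150 nM, within 30 nM to 1000 nM, meaning an expected step of a 190-fold lower number from compound 3 to compound 4 (2.28 log units; beyond the scatter).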

Compound 4, half-maximal inhibitory concentration: 99200 nM
Estimate against measurement, compound 4: 660-fold (2.82 log units) below; measured number above the stated range.
By their numbers in this assay, from the lowest: compound 2; then compound 3; then compounds 1 and 4 (each within the scatter of the next).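

Dimethylamino in place of methoxy on this aromatic carbon has no single effect in this assay; with furan-3-yl on the core, it gives a 3.4-fold higher number from compound 3 to compound 4 (0.54 log units; beyond the scatter). The outcome differs with the other group on the core: the same change on two cores in this assay, a 240-fold lower number (2.38 log units; beyond the scatter) from compound 1 to compound 2 and a 3.4-fold higher number (0.54 log units; beyond the scatter) from compound 3 to compound 4, 830-fold (2.92 log units) apart, beyond the scatter of two such steps. Read the other way, furan-3-yl in place of ethynyl gives a 240-fold higher number from compound 2 to compound 4 (2.38 log units; beyond the scatter), so among these compounds only the pairing of ethynyl with dimethylamino gives a low number: the same change on two cores in this assay, a 3.4-fold lower number (0.53 log units; beyond the scatter) from compound 1 to compound 3 and a 240-fold higher number (2.38 log units; beyond the scatter) from compound 2 to compound 4, 830-fold (2.92 log units) apart, beyond the scatter of two such steps.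

These compounds do not show why the two groups behave differently together. As far as these compounds go, it also remains open whether a smaller amine, such as methylamino, would follow dimethylamino with ethynyl or with furan-3-yl.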